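Tert-Butyl in Place of Ethyl: What Compound 4 Should Show

The source may report more compounds than this note shows. Statements on the series, on what has been measured and on what is new or still open speak of the compounds shown alone.

Of the compounds shown here, three have so far been measured in an ADME assay on the whole organism with Oryza sativa as the target, tested at 0.1 uM; a lower number here means a stronger effect, a higher number a weaker effect of the compound at the concentration tested. Compound 1 `CCc1cccc(NC(=O)N[C@@H](C)c2ccccc2)c1` gives 100%, compound 2 `CCc1ccc(NC(=O)N[C@H](C)c2ccccc2)cc1` gives 95%, and compound 3 `CCc1ccc(NC(=O)N[C@@H](C)c2ccccc2)cc1` gives 99%. These three numbers all lie within the usual scatter of one another, so compound 2 cannot be set apart from the other two on the numbers alone. Among the compounds with values here, the only step between two compounds that differ in a single place is a number 4 percentage points higher from compound 2 to compound 3 (within the scatter), and that step rests on (the fact that compounds 2 and 3 differ only in the configuration as drawn); it concerns the configuration at the saturated chain carbon and leaves the groups on the aromatic ring untouched.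

Compound 4 `C[C@@H](NC(=O)Nc1ccc(C(C)(C)C)cc1)c1ccccc1` has not yet been measured. It differs from compound 2 by tert-butyl in place of ethyl on an aromatic carbon. Within the data shown here, no measured step alters a group on the aromatic ring, so none bears directly on this change; the one step available stayed within the scatter, and the whole series sits close together. Compound 4 is therefore expected to land near compound 2, with a step of a number 1 percentage points lower from compound 2 to compound 4 (within the scatter), meaning no movement beyond the scatter. The estimate for compound 4 is 94%, expected to fall between 80% and 100%.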

Compound 4, a percentage reported as activity, at one concentration (the size of the read-out at that concentration, not a potency): 100%
Compound 4: middle estimate off by 6 percentage points, on the low side; measured number inside the range.
By their numbers in this assay, from the lowest: compounds 2, 3, 1 and 4 (each within the scatter of the next).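

Within the data shown here, on the aromatic carbon carrying this group, the earlier compounds showed no change of group at all, and the first such change, tert-butyl in place of ethyl, gives a number 5 percentage points higher from compound 2 to compound 4 (within the scatter) in this assay and so does not set the two compounds apart. Going from 2 heavy atoms to 4, with no ring, hydrogen-bond donor, hydrogen-bond acceptor or net charge entering, therefore leaves the read-out indistinguishable from that of compound 2 at the one concentration tested. Nothing on record speaks to why this change behaves as it does.

Still open is whether this place responds to anything other than a group of carbon alone: an amine, a carboxylic acid or a methoxy group on the same aromatic carbon could yet separate from compound 2, while the two groups shown do not. Also open is whether any change to the shared core can produce a number beyond the scatter of these compounds, and whether the configuration at the saturated chain carbon would count for more with tert-butyl on the ring than it did with ethyl.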